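Piperidine in place of thiomorpholine on the thiocarbonyl carbon

This account rests on a few compounds, and the source may have more. Where it says the series, first, only, none or still open, it means among the compounds named here.

Measured in a functional assay on HeLa cells (Homo sapiens) for cytotoxicity, read by MTT assay, with a stated time of 72 h, tested at 100 uM; on this read-out higher numbers stand for more inhibition of growth at the one concentration tested and lower numbers for less inhibition of growth:
compound 1 `N/C(=N\NC(=S)N1CCOCC1)c1ccccn1`: 87.2%
compound 2 `Cc1cccc(/C(N)=N/NC(=S)N2CCSCC2)n1`: 81.6%
compound 3 `N/C(=N\NC(=S)N1CCSCC1)c1ccccn1`: 88.7%

Compound 3 sits among three numbers that all fall within the usual scatter of one another: the step of a number 1.5 percentage points higher from compound 1 to compound 3 (within the scatter) and the step of a number 7.1 percentage points higher from compound 2 to compound 3 (within the scatter) are both too small to be read as real differences, so nothing separates compound 3 from compound 1 or compound 2 on these data.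

Compound 4 `N/C(=N\NC(=S)N1CCCCC1)c1ccccn1` is not yet measured. The change from compound 3 is piperidin-1-yl in place of thiomorpholin-4-yl on a thiocarbonyl carbon. The step that bears on it most directly is a number 1.5 percentage points higher from compound 1 to compound 3 (within the scatter), since it also swaps one six-membered non-aromatic ring with two hetero atoms for another on the same thiocarbonyl carbon and left the read-out unchanged beyond the scatter. The step of a number 7.1 percentage points higher from compound 2 to compound 3 (within the scatter) concerns a different position and is also within the scatter. Among the measured compounds shown here, no measured step alters the count of hetero atoms in that ring, so the expectation rests on the single ring swap already seen.

Compound 4 is therefore expected to show a step of a number 2.7 percentage points lower from compound 3 to compound 4 (within the scatter), that is, no change beyond the scatter. Compound 4 is estimated at 86%, with a range from 72% to 95%.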

Compound 4, percent growth inhibition at one concentration: 86%
Estimate against measurement, compound 4: no gap at the digits printed, within the range that was stated.
By their numbers in this assay, from the lowest: compounds 2, 4, 1 and 3 (each within the scatter of the next).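

In this assay, the swap on the thiocarbonyl carbon gives a number 2.7 percentage points lower from compound 3 to compound 4 (within the scatter) and a number 1.2 percentage points lower from compound 1 to compound 4 (within the scatter). The earlier ring swap only exchanged one ring with 2 hetero atoms for another, whereas piperidin-1-yl has a ring with 1 hetero atom, so this position now tolerates a change in hetero atom count with no shift beyond the scatter, and the second hetero atom of morpholin-4-yl or thiomorpholin-4-yl is not needed to keep the read-out in this range. No measured evidence bears on why these rings read alike.

On these data alone, whether an open-chain dimethylamino group or a piperazin-1-yl ring carrying a free amine on the thiocarbonyl carbon would hold the read-out remains open. A read-out at one concentration also leaves open whether compound 1, compound 3 and compound 4 would separate at lower concentrations.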